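A Cyclohexyl Ring in Place of the Trifluoromethylphenyl Arm

This account rests on a few compounds, and the source may have more. Where it says the series, first, only, none or still open, it means among the compounds named here.

Compound 1 `FC(F)(F)c1ccc(-c2ccc3c(NCCCNCc4ccco4)ccnc3c2)cc1` belongs to a set of three compounds that share one core and differ only in the ring attached to the saturated chain carbon bound to the amine nitrogen. In a physicochemical assay for acid dissociation, compound 1 gives 9.47. Compound 2 `COc1ccc(F)cc1CNCCCNc1ccnc2cc(-c3ccc(C(F)(F)F)cc3)ccc12` gives 9.47, and compound 3 `COc1cccc(CNCCCNc2ccnc3cc(-c4ccc(C(F)(F)F)cc4)ccc23)c1O` gives 9.47. Compound 1 thus stands level with both at the digits shown: the steps of no change at the digits printed from compound 1 to compound 2 (within the scatter), no change at the digits printed from compound 1 to compound 3 (within the scatter) and no change at the digits printed from compound 2 to compound 3 (within the scatter) all lie within the scatter.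

Compound 4 `c1coc(CNCCCNc2ccnc3cc(C4CCCCC4)ccc23)c1` is not yet measured. It differs from compound 1 at the far end of the molecule: cyclohexyl in place of 4-(trifluoromethyl)phenyl on an aromatic carbon. Within the data shown here, no measured step touches this position. The steps that exist, no change at the digits printed from compound 1 to compound 2 (within the scatter) and no change at the digits printed from compound 1 to compound 3 (within the scatter), change the group on the saturated chain carbon bound to the amine nitrogen and leave the acid dissociation constant where it was, so they offer only an indirect guide. With nothing in the data pointing to a shift, the expected step is a number 0.03 log units higher from compound 1 to compound 4 (within the scatter), none beyond the scatter. Compound 4 is estimated at 9.5, with a range from 9.1 to 9.9.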

Compound 4, acid dissociation constant: 9.47
Beside the measured number, compound 4's estimate is 0.03 log units above it, within the range that was stated.
By their numbers in this assay, from the lowest: compounds 1, 2, 3 and 4 (each within the scatter of the next).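

In this assay, the far end of the molecule now has a measured step of its own, and the cyclohexyl swap gives no change at the digits printed from compound 1 to compound 4 (within the scatter) on this aromatic carbon. The earlier steps shown here changed only the ring on the saturated chain carbon bound to the amine nitrogen, whereas this one shows that a non-aromatic ring of carbon only and 4-(trifluoromethyl)phenyl read alike at this second position, at least with furan-2-yl at the other end. Nothing measured here accounts for this result.

Going by these compounds, what an amine or a carboxylic acid on this aromatic carbon would read remains open. So does whether a longer chain in place of the present saturated chain would leave the number level with these four compounds.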